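This account rests on a few compounds, and the source may have more. Where it says the series, first, only, none or still open, it means among the compounds named here.

In a functional assay on the whole organism for inhibition, with Mythimna separata as the target, with a stated time of 5 days (a lower number here means that less compound is needed, a higher number that more compound is needed for the effect), compound 3 `CC(C)(C)n1ncc(OCc2nnc(-c3ccccc3F)s2)c(Cl)c1=O` gives 121 ug/mL and compound 1 `CC(C)(C)n1ncc(OCc2nnc(-c3ccc(Cl)cc3Cl)s2)c(Cl)c1=O` gives 62.2 ug/mL, so these two values lie within the usual scatter of each other. Compound 2 `Cc1cc(C)cc(-c2nnc(COc3cnn(C(C)(C)C)c(=O)c3Cl)s2)c1` gives > 300 ug/mL, which is a limit of the assay and not a number. Compound 4 `CC(C)(C)n1ncc(OCc2nnc(-c3ccc(F)cc3)s2)c(Cl)c1=O` carries 4-fluorophenyl in place of 2-fluorophenyl on an aromatic carbon. Three measured steps changed the group on that same carbon. a 1.9-fold higher number from compound 1 to compound 3 (0.29 log units; within the scatter) stayed within the scatter, while an at least 4.8-fold higher number from compound 1 to compound 2 (0.68 log units; beyond the scatter) and an at least 2.4-fold lower number from compound 2 to compound 3 (0.39 log units; beyond the scatter) went beyond it. None of them swaps one fluorophenyl for another, so no clear direction is expected. The estimated step is a 1.2-fold lower number from compound 3 to compound 4 (0.06 log units; within the scatter), expected to stay within the scatter. Compound 4 is expected at 105 ug/mL, with an estimated range of 40 ug/mL to 280 ug/mL.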

Compound 4, half-maximal effective concentration: 21.5 ug/mL
Compound 4: middle estimate off by 4.9-fold (0.69 log units), on the high side; measured number outside the range, below it.
By their numbers in this assay, from the lowest: compound 4; then compounds 1 and 3 (each within the scatter of the next). At a limit, above all of these: compound 2.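

In this assay, moving the fluorine from 2-fluorophenyl to 4-fluorophenyl gives a 5.6-fold lower number from compound 3 to compound 4 (0.75 log units; beyond the scatter) with the same atoms, so on this carbon the place of the fluorine on the phenyl ring matters, not only which atoms the group holds. For the compounds shown here, compound 4 also has the lowest number so far, as a 2.9-fold lower number from compound 1 to compound 4 (0.46 log units; beyond the scatter) shows against the 2,4-dichlorophenyl group. Compound 2 stands at a limit and not at a number, so an at least 13-fold lower number from compound 2 to compound 4 (1.14 log units; beyond the scatter) gives only a bound.

From the compounds shown here alone, whether this gain belongs to fluorine itself stays open. Plain phenyl, 4-chlorophenyl or 4-methoxyphenyl on this carbon would test that.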